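The source may report more compounds than this note shows. Statements on the series, on what has been measured and on what is new or still open speak of the compounds shown alone.

Measured so far in a functional assay on A549 cells (Homo sapiens) for inhibition, read by MTT assay, with a stated time of 24 h; on this read-out lower numbers stand for stronger inhibition and higher numbers for weaker inhibition:
compound 1 `CCCCCCCCn1cc(COC2(C(F)(F)F)Oc3ccccc3C=C2C(=O)OCC)nn1` gives > 150000 nM, which is a limit of the assay and not a number.
compound 2 `CCOC(=O)C1=Cc2ccccc2OC1(OCc1cc(-c2ccc(Cl)cc2)no1)C(F)(F)F` gives 19100 nM.
compound 3 `O=C(O)C1=Cc2ccccc2OC1(OCc1cc(-c2ccc3ccccc3c2)no1)C(F)(F)F` gives > 150000 nM, again a limit of the assay rather than a number.

Compound 1 therefore stands at the limit of > 150000 nM in this assay, at which 2 of the 3 values shown sit. Compound 3 sits at that same limit, and only compound 2 returns a measured number in this assay. For the measured compounds named here, no two of the measured compounds differ from each other in a single place, so no measured step says how much a change on the saturated chain carbon bound to an aromatic nitrogen is worth here.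

Compound 4 `CCOC(=O)C1=Cc2ccccc2OC1(OCc1cn(CC(=O)Nc2ccc(OC)cc2)nn1)C(F)(F)F` has not yet been measured. It differs from compound 1 as follows: (4-methoxyphenyl)carbamoyl in place of heptyl on a saturated chain carbon bound to an aromatic nitrogen. The heptyl chain of compound 1 has no ring and no hydrogen-bond donor or acceptor; the entering group brings a six-membered aromatic ring, one donor and two acceptors.

Because compound 1 sits at the limit of > 150000 nM in this assay, at which 2 of the 3 values shown sit, any gain for compound 4 can only be read against that limit, and an improvement beyond the scatter in the direction of stronger inhibition is expected, as an at least 1.8-fold lower number from compound 1 to compound 4 (0.27 log units; that floor lies within the scatter). The estimated value of compound 4 in this assay is 80000 nM, with a range from 20000 nM to 200000 nM, and a fair chance that only a limit is again returned.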

Compound 4, half-maximal inhibitory concentration: 29400 nM
The estimate for compound 4 lay 2.7-fold (0.43 log units) above the measured number; low and high end bracket the measured number.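

In this assay, for the compounds shown here, the position on a saturated chain carbon bound to an aromatic nitrogen proves responsive, the first such reading: (4-methoxyphenyl)carbamoyl in place of heptyl gives an at least 5.1-fold lower number from compound 1 to compound 4 (0.70 log units; beyond the scatter), and compound 4 returns a measured number on the core of compound 1. Compound 1 gives > 150000 nM, which is a limit of the assay and not a number. The true size of this step stays unknown and only its lower bound can be read, because the starting point is such a limit: the limit of > 150000 nM in this assay, at which 2 of the 4 values shown sit.

A single replacement at this position cannot divide the step among the aromatic ring, the carbamoyl group and the methoxy group that enter together, and an unsubstituted phenyl carbamoyl or a plain primary amide on the same chain carbon would begin to separate them. Going by these compounds, whether a carboxylic acid or an amine in that place would keep the step, and whether any chain length there lifts a compound off the limit, also remains open.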